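This account rests on a few compounds, and the source may have more. Where it says the series, first, only, none or still open, it means among the compounds named here.

Measured in a functional assay on SW-620 cells (Homo sapiens) for cytotoxicity, read by MTT assay, with stated times of 4 h and 72 h, tested at 2 uM; on this read-out higher numbers stand for weaker inhibition and lower numbers for stronger inhibition:
compound 1 `COc1ccc(/C=C/C(=O)c2ccc(Nc3cc(C)nc4nc(SCc5nc6ccccc6[nH]5)nn34)cc2)cc1`: 170 nM
compound 2 `Cc1cc(Nc2ccc(C(=O)/C=C/c3ccccc3)cc2)n2nc(SCc3nc4ccccc4[nH]3)nc2n1`: 130 nM
compound 3 `Cc1cc(Nc2ccc(C(=O)/C=C/c3ccc4ccccc4c3)cc2)n2nc(SCc3nc4ccccc4[nH]3)nc2n1`: 5 nM

Within the data shown here, compound 3 stands lowest of the three at 5 nM and so shows the strongest inhibition in this assay so far. The next compound to consider, compound 4 `Cc1cc(Nc2ccc(C(=O)/C=C/c3ccc(Cl)cc3)cc2)n2nc(SCc3nc4ccccc4[nH]3)nc2n1` is still unmeasured. The change (4-chlorophenyl in place of naphthalen-2-yl on a double-bonded chain carbon bound to a double-bonded chain carbon) puts 4-chlorophenyl in place of naphthalen-2-yl on a double-bonded chain carbon bound to a double-bonded chain carbon.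

Two measured steps touched this same place: a 26-fold lower number from compound 2 to compound 3 (1.41 log units; beyond the scatter) and a 34-fold lower number from compound 1 to compound 3 (1.53 log units; beyond the scatter) are both large, and each ends at naphthalen-2-yl after starting from a single ring. Among the single rings, a 1.3-fold lower number from compound 1 to compound 2 (0.12 log units; within the scatter) stays within the scatter, though no measured compound carries chlorine. A return to a single ring should therefore give back most of that large gain. For compound 4 the expected result is a large step towards a higher number, estimated as a 14-fold higher number from compound 3 to compound 4 (1.15 log units; beyond the scatter) in this assay for this change. The estimate for compound 4 is 70 nM (expected range 20 nM to 220 nM).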

Compound 4, half-maximal inhibitory concentration: 230 nM
Compound 4: middle estimate off by 3.3-fold (0.52 log units), on the low side; measured number outside the range, above it.
By their numbers in this assay, from the lowest: compound 3; then compounds 2, 1 and 4 (each within the scatter of the next).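

In this assay, going from naphthalen-2-yl to 4-chlorophenyl gives a 46-fold higher number from compound 3 to compound 4 (1.66 log units; beyond the scatter) and so shows that the large steps seen earlier also appear with a third single ring. Chloro does not set this ring apart from the other single rings, with a 1.8-fold higher number from compound 2 to compound 4 (0.25 log units; within the scatter) and a 1.4-fold higher number from compound 1 to compound 4 (0.13 log units; within the scatter), so hydrogen, methoxy and chloro on the aromatic carbon cannot be told apart here, and among these four compounds only compound 3 stands apart. Nothing measured here explains the gap between naphthalen-2-yl and the single rings.

From the compounds shown here alone, it remains open whether a single ring carrying an amine or a carboxylic acid would fall with compound 1, compound 2 and compound 4. A longer chain in place of naphthalen-2-yl is also untested territory among the compounds shown.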